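Working notes: from compound 3 to compound 4

This account rests on a few compounds, and the source may have more. Where it says the series, first, only, none or still open, it means among the compounds named here.

Measured so far in a functional assay on cells (T-cell line, Homo sapiens) for inhibition; on this read-out lower numbers stand for stronger inhibition and higher numbers for weaker inhibition:
compound 1 `COc1ccc(CCCN2CCC(CO)CC2)cc1`, compound 1 gives > 20000 nM, a limit
compound 2 `COc1ccc(CCCN2CCC(COC(c3ccc(Cl)cc3)c3ccc(Cl)cc3)CC2)cc1`, compound 2 gives 1100 nM
compound 3 `CN1CCC(COC(c2ccccc2)c2ccccc2)CC1`, compound 3 gives > 20000 nM, a limit

Compound 3 stands at the limit of > 20000 nM in this assay, at which 2 of the 3 values shown sit, so only a limit is known for it. For the measured compounds named here, compound 2 is the one value with a number in this assay.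

Compound 4 `CCCCCCN1CCC(COC(c2ccccc2)c2ccccc2)CC1` differs from compound 3 by pentyl in place of hydrogen on a saturated chain carbon bound to an amine nitrogen in a ring. Going by the values given here, no measured pair shows this change directly. Compound 2 gives 1100 nM with a larger substituent in that region, so some gain is expected, but compound 2 also differs elsewhere. The step expected from compound 3 to compound 4 is an at least 2.2-fold lower number from compound 3 to compound 4 (0.34 log units; beyond the scatter). There is a fair chance that for compound 4 only a limit is reported again. Compound 4 is estimated at 9000 nM, range 2500 nM to 30000 nM.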

Compound 4, half-maximal inhibitory concentration: 5500 nM
Compound 4: the middle estimate sits 1.6-fold (0.21 log units) above what was measured, within the range that was stated.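

In this assay, pentyl in place of hydrogen on a saturated chain carbon bound to an amine nitrogen in a ring gives an at least 3.6-fold lower number from compound 3 to compound 4 (0.56 log units; beyond the scatter), the only one-place change shown so far. The same change reads as methyl to hexyl, so chain length at this position alone yields a measurable value on an unchanged core. The size of the step is only a floor, because compound 3 has a limit and not a number: the limit of > 20000 nM in this assay, at which 2 of the 4 values shown sit.

As far as these compounds go, whether a longer chain or a shorter one such as propyl would give a lower number remains open. Also open, from the compounds shown here alone, is how a chain ending in a carboxylic acid would read.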